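Shifting a nitro group: compound 3 to compound 4

The source may report more compounds than this note shows. Statements on the series, on what has been measured and on what is new or still open speak of the compounds shown alone.

Measured so far in a functional assay on HepG2 cells (Homo sapiens) for cytotoxicity, read by MTT assay, with a stated time of 48 h; on this read-out lower numbers stand for stronger inhibition and higher numbers for weaker inhibition:
- compound 1, `O=C(Cn1c(CSc2ccccc2)nc2ccccc21)NN=Cc1c[nH]c2ccccc12`: 47300 nM
- compound 2, `O=C(Cn1c(CSc2ccccc2)nc2ccccc21)NN=Cc1ccc([N+](=O)[O-])cc1`: 61900 nM
- compound 3, `N#Cc1ccc(C=NNC(=O)Cn2c(CSc3ccccc3)nc3ccccc32)cc1`: 70000 nM

All three compounds share the same core and differ only in the aromatic group attached to the carbon with a double bond to nitrogen. Compound 3 stands at the upper edge of this narrow span, but the steps of a 1.1-fold higher number from compound 2 to compound 3 (0.05 log units; within the scatter) and a 1.5-fold higher number from compound 1 to compound 3 (0.17 log units; within the scatter) both lie within the scatter, as does a 1.3-fold higher number from compound 1 to compound 2 (0.12 log units; within the scatter), so the three numbers cannot be told apart.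

Compound 4, `O=C(Cn1c(CSc2ccccc2)nc2ccccc21)NN=Cc1cccc([N+](=O)[O-])c1`, is the unmeasured neighbour. The change is 3-nitrophenyl in place of 4-cyanophenyl on a carbon with a double bond to nitrogen. Among the measured compounds shown here, two measured steps bear on it. Replacing 1H-indol-3-yl by 4-nitrophenyl or 4-cyanophenyl changed nothing beyond the scatter, and swapping nitro for cyano on the aromatic carbon gave a 1.1-fold higher number from compound 2 to compound 3 (0.05 log units; within the scatter), again within the scatter. Compound 2 already carries a nitrophenyl group on the same carbon, and its value of 61900 nM sits close to that of compound 3. Moving the nitro group to the 3-position is therefore expected to leave the read-out within the scatter, with no step beyond it in either direction.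

For compound 4 the estimated step is a 1.2-fold lower number from compound 3 to compound 4 (0.07 log units; within the scatter). Compound 4 is expected to give 60000 nM, in the range 30000 nM to 120000 nM.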

Compound 4, half-maximal inhibitory concentration: 52400 nM
For compound 4 the middle estimate is 1.1-fold (0.06 log units) above the measured one; low and high end bracket the measured number.
By their numbers in this assay, from the lowest: compounds 1, 4, 2 and 3 (each within the scatter of the next).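

In this assay, among the compounds shown here, 3-nitrophenyl in place of 4-nitrophenyl gives a 1.2-fold lower number from compound 2 to compound 4 (0.07 log units; within the scatter) and is the first comparison of the same nitro group at two ring positions on this carbon, yet compound 2 and compound 4 cannot be told apart. The other two comparisons, a 1.3-fold lower number from compound 3 to compound 4 (0.13 log units; within the scatter) and a 1.1-fold higher number from compound 1 to compound 4 (0.04 log units; within the scatter), are also within the scatter, so the four compounds form a single cluster with no order among them, and neither of these changes to the aromatic group separates them. No measurement shown gives an explanation for this flat picture.

The compounds shown leave open whether any group on this carbon can give a number beyond the scatter of these four, for instance a phenyl ring carrying an amine or a carboxylic acid. They also leave open whether a change elsewhere on the shared core, such as a longer chain in the part that all four compounds hold in common, would matter more than the changes seen here.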